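The source may report more compounds than this note shows. Statements on the series, on what has been measured and on what is new or still open speak of the compounds shown alone.

Measured so far in a functional assay on the whole organism with Rattus norvegicus as the target; a lower number here means that less compound is needed, a higher number that more compound is needed for the effect:
- Compound 1 `CCCCn1c(=N)sc2cc(OC(F)(F)F)ccc21`: 10 mg/kg
- Compound 2 `CNS(=O)(=O)CCn1c(=N)sc2cc(OC(F)(F)F)ccc21`: 4 mg/kg

Compound 2 holds the lower of these two numbers, so less of it is needed. Compound 3 `N=c1sc2cc(OC(F)(F)F)ccc2n1CCO` has not been measured yet. It differs from compound 2 as follows: hydroxy in place of methylsulfamoyl on a saturated chain carbon, two bonds along the chain from an aromatic nitrogen. Going by the values given here, only one measured step bears on this place, a 2.5-fold lower number from compound 1 to compound 2 (0.40 log units; beyond the scatter), which is modest and involves a different group, so it is a loose guide. Losing the methylsulfamoyl might give back part of that step. A small rise is therefore expected, possibly no larger than the usual scatter: a 1.8-fold higher number from compound 2 to compound 3 (0.24 log units; within the scatter). The estimate for compound 3 is 7 mg/kg, with an expected range from 2.5 mg/kg to 20 mg/kg.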

Compound 3, dose for half-maximal effect: 8 mg/kg
Compound 3: the middle estimate sits 1.1-fold (0.06 log units) below what was measured; the measured number falls inside the stated range.
By their numbers in this assay, from the lowest: compounds 2, 3 and 1 (each within the scatter of the next, the first and the last beyond it).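

On this chain, swapping methylsulfamoyl for hydroxy gives, in this assay, a 2.0-fold higher number from compound 2 to compound 3 (0.30 log units; within the scatter), while swapping ethyl for hydroxy gives a 1.3-fold lower number from compound 1 to compound 3 (0.10 log units; within the scatter). Compound 3 therefore cannot be told apart from either compound 2 or compound 1, even though those two differ beyond the scatter, so the methylsulfamoyl group is not shown to be needed for the lower number. No measurement here explains this result.

Going by these compounds, whether an amine, a carboxylic acid or a longer chain at this place would shift the number beyond the scatter stays open.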